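Second chloro on the pyridine ring: compound 3

This account rests on a few compounds, and the source may have more. Where it says the series, first, only, none or still open, it means among the compounds named here.

Compound 2 `Clc1ccc(N2C[C@H]3CCNC[C@H]32)cn1` gives 216 nM in a functional assay on HEK293 cells for agonist activity at Neuronal acetylcholine receptor; alpha4/beta2 (Homo sapiens), read by FLIPR (a lower number here means that less compound is needed, a higher number that more compound is needed for the effect), the lowest of the two numbers here; compound 1 `c1cncc(N2C[C@H]3CCNC[C@H]32)c1` gives 1400 nM. Among the measured compounds shown here, the only step so far is a 6.5-fold lower number from compound 1 to compound 2 (0.81 log units; beyond the scatter), which bears directly on compound 3 `Clc1cc(N2C[C@H]3CCNC[C@H]32)cnc1Cl`: here the change is chloro in place of hydrogen on an aromatic carbon. A second chloro need not repeat the first gain, so compound 3 is expected to show only a small shift, a 1.4-fold lower number from compound 2 to compound 3 (0.16 log units; within the scatter), possibly within the scatter. The estimate for compound 3 is 150 nM, with a range from 40 nM to 600 nM.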

Compound 3, half-maximal effective concentration: 176 nM
The estimate for compound 3 lay 1.2-fold (0.07 log units) below the measured number, within the range that was stated.
By their numbers in this assay, from the lowest: compounds 3 and 2 (each within the scatter of the next); then compound 1.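

In this assay, adding a chloro ortho to a chloro group, two atoms from the ring nitrogen, gives a 1.2-fold lower number from compound 2 to compound 3 (0.09 log units; within the scatter) and so no real change. The earlier gain of a 6.5-fold lower number from compound 1 to compound 2 (0.81 log units; beyond the scatter) from the first chloro is therefore not repeated here, and this position accepts a second chloro without a clear gain or loss. No available evidence explains this result. On these data alone, it remains open whether a different group at this position, such as methoxy or an amine, would shift the number beyond the scatter.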